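The source may hold more compounds than are shown below. What is called first, only, known or untested is meant among the compounds shown, and "the series" means these compounds.

Measured in an assay for inhibition of histone-lysine N-methyltransferase, H3 lysine-79 specific (Homo sapiens), with stated times of 15 min and 120 min, tested at 50 uM; on this read-out higher numbers stand for more inhibition at the one concentration tested (going by the name of the read-out) and lower numbers for less inhibition:
compound 1 `CCc1nnc2sc(-c3cccc(F)c3)nn12` gives 13%
compound 2 `Fc1cccc(-c2nn3c(CN4CCCCC4)nnc3s2)c1` gives 6%

Among the compounds with values here, compound 2 and compound 1 sit within the scatter of each other; the only measured step, a number 7 percentage points lower from compound 1 to compound 2 (within the scatter), is within the scatter, so compound 2 cannot be placed apart from compound 1 on these numbers.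

Compound 3 `Fc1cccc(-c2nn3c(-c4cccc(F)c4)nnc3s2)c1` differs from compound 2 by 3-fluorophenyl in place of (piperidin-1-yl)methyl on an aromatic carbon. Within the data shown here, the single measured step touched the same position but exchanged one saturated substituent for another, and it was within the scatter; no measured step covers an aromatic ring entering here. The expected step of a number 4 percentage points higher from compound 2 to compound 3 (within the scatter) is therefore none beyond the scatter. Compound 3 is estimated at 10%, in the range -5% to 25%.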

Compound 3, a percentage reported as inhibition, at one concentration (the size of the read-out at that concentration, not a potency): 11%
The estimate for compound 3 lay 1 percentage points below the measured number; low and high end bracket the measured number.
By their numbers in this assay, from the lowest: compounds 2, 3 and 1 (each within the scatter of the next).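

Within the data shown here, at this position, on an aromatic carbon of a five-membered aromatic ring with 3 nitrogen, an aromatic ring now enters for the first time: in this assay 3-fluorophenyl in place of (piperidin-1-yl)methyl gives a number 5 percentage points higher from compound 2 to compound 3 (within the scatter) and 3-fluorophenyl in place of ethyl gives a number 2 percentage points lower from compound 1 to compound 3 (within the scatter) and both steps stay within the scatter. Ethyl, (piperidin-1-yl)methyl and 3-fluorophenyl therefore cannot be told apart here. No evidence bears on this result.

Open, going by these compounds, is whether any other group at this position, such as a carboxylic acid or a primary amine, would move the number beyond the scatter.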